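From heptyl to 3-phenoxypropyl on the shared core

A few compounds are considered here, and "the series" means these few. Any claim that something is new, unique, unknown or untested is made for them only; others in the source may bear on it.

In a functional assay on A549 cells (Homo sapiens) for antiproliferative activity, read by MTT assay, with a stated time of 48 h (a higher number here means a weaker inhibitor of growth, a lower number a stronger inhibitor of growth), compound 1 `CCCCCN(Cc1ccc(C(=O)NO)cc1)c1ncc(-c2ccc(C)cc2)s1` gives 9140 nM, compound 2 `Cc1ccc(-c2cnc(N(Cc3ccccc3)Cc3ccc(C(=O)NO)cc3)s2)cc1` gives 4410 nM and compound 3 `CCCCCCCCN(Cc1ccc(C(=O)NO)cc1)c1ncc(-c2ccc(C)cc2)s1` gives 4630 nM. Compound 3 stands within the scatter of both others, as shown by a 1.0-fold higher number from compound 2 to compound 3 (0.02 log units; within the scatter) and by a 2.0-fold lower number from compound 1 to compound 3 (0.30 log units; within the scatter). Only a 2.1-fold lower number from compound 1 to compound 2 (0.32 log units; beyond the scatter) goes beyond the scatter, and it is modest.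

The next structure is compound 4 `Cc1ccc(-c2cnc(N(CCCCOc3ccccc3)Cc3ccc(C(=O)NO)cc3)s2)cc1`. The change is phenoxy in place of butyl on a saturated chain carbon, four bonds along the chain from a nitrogen on an aromatic ring. Cut one bond further out, the same difference reads heptyl to 3-phenoxypropyl.

Going by the values given here, no measured compound carries phenoxy, so the evidence is indirect. Among the compounds with values here, the closest precedent is the exchange of heptyl and phenyl at the chain carbon bound to the nitrogen, where a 1.0-fold higher number from compound 2 to compound 3 (0.02 log units; within the scatter) stays within the scatter. The chain extension in a 2.0-fold lower number from compound 1 to compound 3 (0.30 log units; within the scatter) is also within the scatter. No step beyond the scatter is therefore expected in this assay. The expected change is a 1.2-fold lower number from compound 3 to compound 4 (0.06 log units; within the scatter). For compound 4 the estimated value is 4000 nM, with an expected range of 1800 nM to 9000 nM.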

Compound 4, concentration for 50% growth inhibition: 14200 nM
For compound 4 the middle estimate is 3.6-fold (0.55 log units) below the measured one, and the stated range ends below it.
By their numbers in this assay, from the lowest: compounds 2, 3, 1 and 4 (each within the scatter of the next, the first and the last beyond it).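

In this assay, going by these compounds alone, swapping the group on this nitrogen had so far produced steps at about the edge of the scatter, but phenoxy in place of butyl on a saturated chain carbon, four bonds along the chain from a nitrogen on an aromatic ring, gives a 3.1-fold higher number from compound 3 to compound 4 (0.49 log units; beyond the scatter), the first step from compound 3 to leave the scatter. The exchange of phenyl for 3-phenoxypropyl on the chain carbon bound to the nitrogen gives a step of similar size, a 3.2-fold higher number from compound 2 to compound 4 (0.51 log units; beyond the scatter), so a ring at the end of this chain does not read like the phenyl of compound 2. Against this, a 1.6-fold higher number from compound 1 to compound 4 (0.19 log units; within the scatter) stays within the scatter, so the change costs activity relative to compounds 2 and 3 only, and the phenoxy-ended chain cannot be told apart from the pentyl chain of compound 1.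

No measurement at hand gives a reason for the step. As far as these compounds go, whether the oxygen or the ring of phenoxy carries the step stays open, as does how an amine, a carboxylic acid or a longer chain at the same chain end would read.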